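The compounds below may be only part of what the source reports. "The series", "measured", "known", "first", "only" and "open" are said of these compounds alone.

In a functional assay on the whole organism (strain Wistar) for inhibition, with Rattus norvegicus as the target, read by paw edema, with stated times of 60 min and 3 h, at a dose of 100 mg/kg by the oral route (on this read-out lower numbers stand for less inhibition and higher numbers for more inhibition at the one dose given (going by the name of the read-out)), compound 1 `COc1cc2c(cc1OC)C(CC(N)=O)CC2` gives 30.4%, compound 2 `COc1cc2c(cc1OC)C(CC(=O)N(C)C)CC2` gives 34.8%, and compound 3 `CCNC(=O)CC1CCc2cc(OC)c(OC)cc21` gives 26.1%. Compound 3 carries the smallest of the three numbers, but both gaps lie within the scatter: a number 4.3 percentage points lower from compound 1 to compound 3 (within the scatter) and a number 8.7 percentage points lower from compound 2 to compound 3 (within the scatter). Compound 4 `CCN(CC)C(=O)CC1CCc2cc(OC)c(OC)cc21` differs from compound 3 by ethyl in place of hydrogen on an amide-type nitrogen. The step most alike in kind, ethyl in place of hydrogen on an amide-type nitrogen, is a number 4.3 percentage points lower from compound 1 to compound 3 (within the scatter); the step of dimethylamino in place of amino on a carbonyl carbon, a number 4.4 percentage points higher from compound 1 to compound 2 (within the scatter), was likewise within the scatter. No movement beyond the scatter is therefore expected in this assay; the estimated step is a number 1.9 percentage points higher from compound 3 to compound 4 (within the scatter). Compound 4 is expected to give about 28%, with a range from 15% to 42%.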

Compound 4, a percentage reported as inhibition, in the whole organism at one dose (the size of the read-out at that dose, not a potency): 37.7%
Beside the measured number, compound 4's estimate is 9.7 percentage points below it; the range from low to high includes it.
By their numbers in this assay, from the lowest: compounds 3, 1, 2 and 4 (each within the scatter of the next, the first and the last beyond it).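

For the compounds shown here, on the amide-type nitrogen, ethyl in place of hydrogen now gives in this assay a number 11.6 percentage points higher from compound 3 to compound 4 (beyond the scatter), the only step so far to pass the scatter, while the same replacement gave a number 4.3 percentage points lower from compound 1 to compound 3 (within the scatter) where the nitrogen carried no ethyl. The other two steps to diethylamino do not pass it: a number 2.9 percentage points higher from compound 2 to compound 4 (within the scatter) and a number 7.3 percentage points higher from compound 1 to compound 4 (within the scatter). Nothing in the data shown accounts for this difference between the steps.

As far as these compounds go, whether a propyl group on the nitrogen, a pyrrolidine amide or a carboxylic acid in place of the amide would read differently in this assay stays open.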